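A few compounds are considered here, and "the series" means these few. Any claim that something is new, unique, unknown or untested is made for them only; others in the source may bear on it.

Compound 1 `COc1ccccc1C(=O)Nc1ccc(Sc2nc3ccccc3s2)cc1` and compound 2 `O=C(Nc1ccc(Sc2nc3ccccc3s2)cc1)c1ccccc1` share one core and differ by hydrogen in place of methoxy on an aromatic carbon. In an assay for inhibition of HSP60/HSP10 (Homo sapiens), with a stated time of 60 min (on this read-out higher numbers stand for weaker inhibition and lower numbers for stronger inhibition), compound 1 gives only a limit, > 100000 nM. In this assay compound 2 also gives only a limit, > 100000 nM, so compound 2 stands at the edge of the scale, with no number of its own. The step that the two limits leave unreadable from compound 1 to compound 2 rests on two values that sit at the limit of > 100000 nM in this assay, at which 2 of the 2 values shown sit. Compound 3 `O=C(Nc1ccc(Sc2nc3ccccc3s2)cc1)c1cc(Br)cc(Br)c1` carries 3,5-dibromophenyl in place of phenyl on a carbonyl carbon. Among the compounds with values here, no measured step bears on this change, so the expected step of a number no higher from compound 2 to compound 3 (the limit leaves the size open) has no anchor beyond the two limits. Compound 3 is estimated at 100000 nM, within 20000 nM to 300000 nM, most likely again reported as a limit.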

Compound 3, half-maximal inhibitory concentration: > 100000 nM
Compound 3: no number, only a limit; the forecaster's own chance of this, stated with the estimate: 70%; the middle value lies on the limit itself.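

No step can be read among compound 1, compound 2 and compound 3, because all three sit at the same limit: the limit of > 100000 nM in this assay, at which 3 of the 3 values shown sit.

From the compounds shown here alone, whether any group on the carbonyl carbon would give a readable number in this assay stays open.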